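This account rests on a few compounds, and the source may have more. Where it says the series, first, only, none or still open, it means among the compounds named here.

Compound 1 `CCOC(=O)c1c(-c2cccc(C(F)(F)F)c2)csc1N` is the reference point of this small series. In an assay on CHO-K1 cells for displacement of a labelled ligand from adenosine receptor A1 (Homo sapiens), tested at 10 uM (on this read-out lower numbers stand for less inhibition and higher numbers for more inhibition at the one concentration tested (going by the name of the read-out)), compound 1 gives 93%, the highest of the three numbers to hand. Compound 2 `Nc1scc(-c2cccc(C(F)(F)F)c2)c1C(=O)c1ccccc1` gives 61.1% in the same assay, and compound 3 `CCOC(=O)c1c(N)sc(-c2ccc([N+](=O)[O-])cc2)c1-c1cccc(C(F)(F)F)c1` gives 71.4%. The two steps away from compound 1 run a number 31.9 percentage points lower from compound 1 to compound 2 (beyond the scatter) and a number 21.6 percentage points lower from compound 1 to compound 3 (beyond the scatter); the first comes from phenyl in place of ethoxy on a carbonyl carbon, the second from 4-nitrophenyl in place of hydrogen on an aromatic carbon.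

Compound 4 `CCOC(=O)c1c(N)sc(-c2ccc(Cl)cc2)c1-c1cccc(C(F)(F)F)c1` has not yet been measured. Against compound 1 the change is 4-chlorophenyl in place of hydrogen on an aromatic carbon. Among the compounds with values here, the step that bears on it is the one from compound 1 to compound 3, where an aryl group likewise entered in place of hydrogen on an aromatic carbon and inhibition fell beyond the scatter. A drop of similar size is expected here because the step to compound 3 was a number 21.6 percentage points lower from compound 1 to compound 3 (beyond the scatter); the number for compound 2 does not speak to this change. The expected step is a number 21 percentage points lower from compound 1 to compound 4 (beyond the scatter). The estimate for compound 4 is therefore 72%, with a range from 55% to 88%.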

Compound 4, a percentage reported as inhibition, at one concentration (the size of the read-out at that concentration, not a potency): 58.4%
Compound 4: the middle estimate sits 13.6 percentage points above what was measured; measured number inside the range.
By their numbers in this assay, from the lowest: compounds 4 and 2 (each within the scatter of the next); then compound 3; then compound 1.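

In this assay, the ring carbon next to the ring sulfur has now taken two different aryl groups, and both lower the number beyond the scatter; the new step is a number 34.6 percentage points lower from compound 1 to compound 4 (beyond the scatter). The group on that aryl ring also counts, since chloro in place of nitro gives a number 13 percentage points lower from compound 3 to compound 4 (beyond the scatter), so the outcome at this position depends on more than the presence of an aryl ring. Nothing to hand accounts for either drop.

On these data alone, it remains open whether a methyl group or an unsubstituted phenyl at this position would keep the number closer to that of compound 1, and whether a 4-methoxyphenyl or 4-aminophenyl group would extend the difference seen between chloro and nitro. As far as these compounds go, the effect of these aryl groups with phenyl in place of ethoxy on the carbonyl carbon also remains open.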